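Chloro to trifluoromethyl on the distal ring of compound 2

This account rests on a few compounds, and the source may have more. Where it says the series, first, only, none or still open, it means among the compounds named here.

Measured compounds:
Compound 1 `CCCc1cc(N)c2cc(NC(=O)c3ccc(C(F)(F)F)cc3)ccc2n1`: 10000 nM
Compound 2 `CCCc1cc(N)c2cc(NC(=O)c3ccc(-c4ccc(Cl)cc4)cc3)ccc2n1`: 0.7 nM
Compound 3 `CCCc1cc(N)c2cc(NC(=O)/C=C/c3ccc(O)cc3)ccc2n1`: 1100 nM

In an assay on isolated protein for displacement of a labelled ligand from melanin-concentrating hormone receptor 1 (Homo sapiens) (a higher number here means a weaker inhibitor, a lower number a stronger inhibitor), compound 2 gives 0.7 nM, the lowest of the three numbers; compound 3 gives 1100 nM and compound 1 gives 10000 nM, both far from it and beyond the scatter. Compound 4 `CCCc1cc(N)c2cc(NC(=O)c3ccc(-c4ccc(C(F)(F)F)cc4)cc3)ccc2n1` is yet to be measured. It differs from compound 2 by trifluoromethyl in place of chloro on an aromatic carbon. For the measured compounds named here, only one measured step touches this part of the molecule: a 14000-fold lower number from compound 1 to compound 2 (4.15 log units; beyond the scatter), which shows how strongly this assay responds when the 4-chlorophenyl is present at all. Going by the values given here, no measured pair compares chloro with trifluoromethyl on that outer ring, so the direction of the step from compound 2 to compound 4 cannot be read from the data. Given that the 4-chlorophenyl arrangement is retained in compound 4 and only the substituent on it changes, compound 4 is expected to stay close to compound 2, with a step of a 2.1-fold higher number from compound 2 to compound 4 (0.33 log units; beyond the scatter) and an estimated value of 1.5 nM (range 0.4 nM to 6 nM).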

Compound 4, half-maximal inhibitory concentration: 4.5 nM
Beside the measured number, compound 4's estimate is 3.0-fold (0.48 log units) below it, and the stated range covers the measured number.
By their numbers in this assay, from the lowest: compound 2; then compound 4; then compound 3; then compound 1.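

In this assay, for the compounds shown here, trifluoromethyl in place of chloro on the outer ring gives a 6.4-fold higher number from compound 2 to compound 4 (0.81 log units; beyond the scatter), the first measured comparison of these two groups at this position, and it shows that the chloro group gives the lower number but is not essential for a low one. With trifluoromethyl present on both sides, the other new step is a 2200-fold lower number from compound 1 to compound 4 (3.35 log units; beyond the scatter), so the large gain from the added ring does not depend on chlorine, although the ring's substituent still shifts the number modestly. Nothing available bears on why chloro and trifluoromethyl differ here.

The compounds shown leave open how the unsubstituted phenyl ring compares with these two, so the separate contribution of each substituent cannot be judged. They also leave open whether a methoxy group, a nitrile, an amine or a carboxylic acid on that ring would keep the number this low.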